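From ethyl to chloro: one small swap, one open number

This account rests on a few compounds, and the source may have more. Where it says the series, first, only, none or still open, it means among the compounds named here.

compound 1 `O=C1NCCN1c1ccc(S(=O)(=O)Nc2ccc3[nH]ccc3c2)cc1` gives 87 nM
compound 2 `O=C1NCCN1c1ccc(S(=O)(=O)Nc2ccc(I)cc2)cc1` gives 260 nM
compound 3 `CCc1ccc(NS(=O)(=O)c2ccc(N3CCNC3=O)cc2)cc1` gives 480 nM

All three numbers come from a functional assay on M21 cells (Homo sapiens) for antiproliferative activity, read by sulforhodamine B assay, with a stated time of 48 h (a lower number here means a stronger inhibitor, a higher number a weaker inhibitor), and can be compared directly. Compound 3 stands level with compound 2, and compound 1 has a clearly lower number than compound 3. The next compound, compound 4 `O=C1NCCN1c1ccc(S(=O)(=O)Nc2ccc(Cl)cc2)cc1`, has not yet been measured. It keeps the rest of compound 3 and carries chloro in place of ethyl on an aromatic carbon, para to a large group chloro in place of ethyl on an aromatic carbon in the same ring. Going by the values given here, only one measured step bears on this change, ethyl in place of iodo, and it is a 1.8-fold higher number from compound 2 to compound 3 (0.27 log units; within the scatter) as measured. A single step within the scatter is thin evidence, but in this assay it gives no reason to expect a step beyond the scatter, and no clear direction. The estimated step is a 1.2-fold lower number from compound 3 to compound 4 (0.08 log units; within the scatter) and nothing larger is expected. For compound 4 the estimate is 400 nM as the expected value, with an expected range from 150 nM to 1100 nM for the coming measurement.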

Compound 4, half-maximal inhibitory concentration: 90 nM
For compound 4 the middle estimate is 4.4-fold (0.65 log units) above the measured one, outside the stated range (below it).
By their numbers in this assay, from the lowest: compounds 1 and 4 (each within the scatter of the next); then compounds 2 and 3 (each within the scatter of the next).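

In this assay, chloro in place of ethyl gives a 5.3-fold lower number from compound 3 to compound 4 (0.73 log units; beyond the scatter), and chloro in place of iodo gives a 2.9-fold lower number from compound 2 to compound 4 (0.46 log units; beyond the scatter), so both steps are modest but clear. The earlier swap between iodo and ethyl stayed within the scatter and suggested a position with little response, but the aromatic carbon para to a large group does respond to the group it carries, with chloro standing apart from the other two. Nothing available here explains why chloro differs from iodo and ethyl.

The compounds shown leave open where groups such as fluoro, bromo, methoxy or an amine would fall relative to chloro at this place. They also leave open whether the advantage of chloro holds when another part of the shared core changes.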